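The compounds below may be only part of what the source reports. "The series", "measured", "known", "first", "only" and "open" are said of these compounds alone.

The shared core of compound 1 `O=C(Nc1ccc(Sc2nc3ccccc3s2)c(Cl)c1)c1cc(Br)cc(Br)c1` carries an amide that joins a 3,5-dibromophenyl group to the rest of the molecule. In an assay on isolated protein for inhibition of thiosulfate sulfurtransferase (Homo sapiens), with a stated time of 60 min, in the absence of a further agent (on this read-out higher numbers stand for weaker inhibition and lower numbers for stronger inhibition), compound 1 gives > 100000 nM, which is a limit of the assay and not a number. Compound 2 `O=C(Nc1ccc(Sc2nc3ccccc3s2)cc1)c1cc(Br)cc(Br)c1` is the same molecule with hydrogen in place of chloro on an aromatic carbon, and in this assay compound 2 gives > 100000 nM, again a limit. The step that the two limits leave unreadable from compound 1 to compound 2 therefore cannot be read. The smaller compound 3 `O=C(Nc1cccc(Cl)c1)c1cccc(Br)c1` likewise gives > 100000 nM in this assay, also a limit. Going by the values given here, all three values sit at the limit of > 100000 nM in this assay, at which 3 of the 3 values shown sit, so no measured step tells how any change moves the read-out.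

Compound 4 `O=C(Nc1ccc(Sc2nc3ccccc3s2)c(Cl)c1)c1cc(Br)ccc1O` differs from compound 1 by 5-bromo-2-hydroxyphenyl in place of 3,5-dibromophenyl on a carbonyl carbon. Among the compounds with values here, no measured step bears on this change, because every value shown is at the limit of > 100000 nM in this assay, at which 3 of the 3 values shown sit, and the direction of the expected step that the limit leaves unreadable from compound 1 to compound 4 cannot be grounded in the data. Compound 4 is estimated at 150000 nM in this assay, with a range from 20000 nM to 1000000 nM, most likely again reported only as a limit.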

Compound 4, half-maximal inhibitory concentration: > 100000 nM
Compound 4: only a limit was reported; the forecaster's own chance of this, stated with the estimate: 75%; the middle value lies beyond the limit too.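

In this assay compound 4 gives > 100000 nM as a limit of the assay and not a number. Going by these compounds alone, compound 1 also stands only at a limit, so no step from compound 1 to compound 4 can be read: the limit of > 100000 nM in this assay, at which 4 of the 4 values shown sit. The compounds shown leave open which change, if any, would bring a measurable half-maximal inhibitory concentration.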